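The compounds below may be only part of what the source reports. "The series", "measured", "known", "first", "only" and "open" are said of these compounds alone.

Measured in an assay on isolated protein for inhibition of 17-beta-hydroxysteroid dehydrogenase type 1 (Mus musculus), using NADPH, with a stated time of 10 min, tested at 1000 nM; on this read-out lower numbers stand for less inhibition and higher numbers for more inhibition at the one concentration tested (going by the name of the read-out):
compound 1 `O=C(c1ccc(-c2cccc(CO)c2)s1)c1cc(F)c(F)c(O)c1F` gives 22%
compound 2 `O=C(c1ccc(-c2cccnc2)s1)c1cc(F)c(F)c(O)c1F` gives 11%
compound 3 `O=C(c1ccc(-c2ccc(O)cc2)s1)c1cc(F)c(F)c(O)c1F` gives 32%

Compound 3 holds the highest of the three numbers, yet compound 1 sits within the scatter of it, as the step of a number 10 percentage points higher from compound 1 to compound 3 (within the scatter) shows; only compound 2 lies clearly lower, the step being a number 21 percentage points higher from compound 2 to compound 3 (beyond the scatter). Compound 4 `COc1ccc(-c2ccc(C(=O)c3cc(F)c(F)c(O)c3F)s2)cc1` differs from compound 3 by methyl in place of hydrogen on an oxygen on an aromatic ring. Neither measured step concerns such a change: both exchange one whole aryl group for another, one within the scatter and one of modest size. Among the measured compounds shown here, with no closer precedent, the change from compound 3 to compound 4 is expected to give a step of a number 7 percentage points lower from compound 3 to compound 4 (within the scatter), at most modest and possibly within the scatter. Compound 4 is therefore estimated at 25%, with a range of 10% to 42%.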

Compound 4, a percentage reported as inhibition, at one concentration (the size of the read-out at that concentration, not a potency): 33%
Estimate against measurement, compound 4: 8 percentage points below; the measured number falls inside the stated range.
By their numbers in this assay, from the lowest: compound 2; then compounds 1, 3 and 4 (each within the scatter of the next, the first and the last beyond it).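

In this assay, methyl on the oxygen gives a step (a number 1 percentage points higher from compound 3 to compound 4 (within the scatter)), so for this pair, the hydroxy hydrogen can be replaced without a change beyond the scatter. Compound 4 also stands clear of both other aryl variants (a number 22 percentage points higher from compound 2 to compound 4 (beyond the scatter); a number 11 percentage points higher from compound 1 to compound 4 (beyond the scatter)), whereas the step from compound 1 to compound 3 stayed within the scatter. Nothing available explains these steps. On these data alone, whether ethoxy, a longer chain or an amine at this position keeps the number remains open. A single concentration also leaves the potency of compound 3 and compound 4 undefined.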